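Chloro to hydroxy on the aryl ring: ortho versus meta

The source may hold more compounds than are shown below. What is called first, only, known or untested is meant among the compounds shown, and "the series" means these compounds.

Three compounds of this series have numbers in a functional assay (brain) for displacement of a labelled ligand, with Rattus norvegicus as the target; a lower number here means a stronger inhibitor, a higher number a weaker inhibitor. Compound 1 `CC[C@]1(c2ccccc2Cl)OC[C@H]([C@@H]2CCCCN2)O1` gives 14.3 nM. Compound 2 `CC[C@]1(c2cccc(Cl)c2)OC[C@H]([C@@H]2CCCCN2)O1` gives 59 nM; compound 2 and compound 1 have the same atoms joined differently, and the difference between the two cores is not broken down here. Compound 3 `CC[C@]1(c2ccccc2O)OC[C@H]([C@@H]2CCCCN2)O1` gives 293 nM.

For the measured compounds named here, the one change measured in a single place is hydroxy in place of chloro on an aromatic carbon, which gave a 20-fold higher number from compound 1 to compound 3 (1.31 log units; beyond the scatter). Compound 2 stands between the other two, with compound 1 lower and compound 3 higher, both gaps beyond the scatter.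

Compound 4 `CC[C@]1(c2cccc(O)c2)OC[C@H]([C@@H]2CCCCN2)O1` has not been measured. It differs from compound 2 by hydroxy in place of chloro on an aromatic carbon. Set against the change from compound 1 to compound 3, this is the same kind of change and not the same: there the entering group sits ortho to a large group, here meta to a large group. A single measured instance is all that is available, and it comes from the other place on the ring.

For compound 4 the expected step in this assay is a 12-fold higher number from compound 2 to compound 4 (1.07 log units; beyond the scatter), somewhat smaller than the measured one. This rests on compound 1 and compound 3, where a 20-fold higher number from compound 1 to compound 3 (1.31 log units; beyond the scatter) lay well beyond the scatter. On that basis compound 4 is estimated at 700 nM, expected to fall between 200 nM and 2500 nM.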

Compound 4, inhibition constant: 489 nM
The estimate for compound 4 lay 1.4-fold (0.16 log units) above the measured number; measured number inside the range.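

In this assay, hydroxy in place of chloro on an aromatic carbon gave an 8.3-fold higher number from compound 2 to compound 4 (0.92 log units; beyond the scatter), so the number rose on both cores, and each step lies beyond the scatter. The two steps cannot be told apart in size: the same change on two cores in this assay, a 20-fold higher number (1.31 log units; beyond the scatter) from compound 1 to compound 3 and an 8.3-fold higher number (0.92 log units; beyond the scatter) from compound 2 to compound 4, 2.5-fold (0.39 log units) apart, within the scatter of two such steps Working on these two pairs, the change carries from the core of compound 1 to the core of compound 2 in direction and, within the scatter, in size, but two pairs show neither why chloro is preferred over hydroxy nor whether the same step would appear on any other core in the series.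

Still open, on these data alone, is whether a methoxy group, a fluoro group or an amine on the same aromatic carbon would give a number closer to that of the chloro compounds or to that of the hydroxy compounds. Also open, as far as these compounds go, is whether the step from chloro to hydroxy keeps its direction and size when a longer chain replaces the ethyl group on the shared core.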